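Moving the ring nitrogen in a cinnamamide-type channel blocker

A few compounds are considered here, and "the series" means these few. Any claim that something is new, unique, unknown or untested is made for them only; others in the source may bear on it.

The series is built on a shared core carrying a tert-butylphenyl group and a benzodioxane-type amide, tested in a functional assay on CHO cells for inhibition of transient receptor potential cation channel subfamily V member 1 (Homo sapiens); a higher number here means a weaker inhibitor, a lower number a stronger inhibitor. Compound 1 `CN(C(=O)/C=C/c1ccc(C(C)(C)C)cc1)c1ccc2c(c1)OCCO2` is the simpler member, with the chain carrying only the aryl group and the amide nitrogen bearing a methyl. In this assay compound 1 reaches only the limit of > 4000 nM, which is a limit of the measurement and not a number. Among the measured compounds shown here, compound 2 `CC(C)(C)c1ccc(/C(=C/C(=O)Nc2ccc3c(c2)OCCO3)c2cccnc2)cc1` adds a pyridin-3-yl group on the double-bonded chain carbon and drops the methyl from the amide nitrogen; in this assay compound 2 gives 78 nM, the only actual number among the values shown, the other being (the limit of > 4000 nM in this assay, at which 1 of the 2 values shown sits).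

Compound 3 `CC(C)(C)c1ccc(/C(=C/C(=O)Nc2ccc3c(c2)OCCO3)c2ccncc2)cc1` differs from compound 2 in a single place: pyridin-4-yl in place of pyridin-3-yl on a double-bonded chain carbon bound to an aromatic carbon and a double-bonded chain carbon. For the measured compounds named here, no measured pair in this set shows the effect of such a change, so there is no step to lean on. Moving the ring nitrogen by one position is expected to leave the activity close to that of compound 2, and the step of a 1.5-fold higher number from compound 2 to compound 3 (0.19 log units; within the scatter) is estimated to lie within the usual scatter. Compound 3 is therefore expected to give about 120 nM, with a likely range from 40 nM to 400 nM.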

Compound 3, half-maximal inhibitory concentration: 44 nM
Estimate against measurement, compound 3: 2.7-fold (0.44 log units) above; the range from low to high includes it.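

In this assay, pyridin-4-yl in place of pyridin-3-yl on the double-bonded chain carbon gives a step (a 1.8-fold lower number from compound 2 to compound 3 (0.25 log units; within the scatter)), so this position accepts the ring nitrogen in either of these two placements without a difference that can be told from the scatter. Among the compounds shown here, this is the first comparison in the set between two actual numbers and the first between compounds that differ in one place, as compound 1 stands at a limit (> 4000 nM), which is not a number, and differs from compound 2 in more than one place. Nothing measured here speaks to why the two pyridine groups behave alike, and no data shown bear on a cause.

The compounds shown leave open whether this tolerance extends to pyridin-2-yl, to a plain phenyl group or to a phenyl group carrying an amine or a carboxylic acid on this same chain carbon. They also leave open what the pyridine group and the methyl on the amide nitrogen each contribute alone, as the two changes between compound 1 and compound 2 are not separated.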